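The source may report more compounds than this note shows. Statements on the series, on what has been measured and on what is new or still open speak of the compounds shown alone.

Measured compounds:
Compound 1, `Oc1ccccc1/C=N/c1nnc(SCc2nnc(-c3ccc(F)cc3)o2)s1`, giving 13100 nM
Compound 2, `COc1ccc(-c2nnc(CSc3nnc(/N=C/c4ccccc4O)s3)o2)cc1`, giving 10000 nM

In a functional assay on SMMC-7721 cells (Homo sapiens) for inhibition, read by CCK-8 assay (on this read-out higher numbers stand for weaker inhibition and lower numbers for stronger inhibition), compound 1 gives 13100 nM, while compound 2 gives 10000 nM. Among the measured compounds shown here, compound 2 therefore stands side by side with compound 1 on this assay: the single measured step, a 1.3-fold lower number from compound 1 to compound 2 (0.12 log units; within the scatter), does not separate the two beyond the usual scatter. Compound 3, `O=[N+]([O-])c1cccc(-c2nnc(CSc3nnc(/N=C/c4ccccc4O)s3)o2)c1`, has not yet been tested. Its structural change is 3-nitrophenyl in place of 4-methoxyphenyl on an aromatic carbon. For the measured compounds named here, no measured step involves a nitro group, so the only guide is that exchanging one aromatic group for another in the measured pair left the number essentially where it was; on that basis no shift beyond the scatter is expected here either. Compound 3 is accordingly estimated to give 10000 nM, with a range from 4000 nM to 25000 nM. That estimate corresponds to an expected step of no change at the digits printed from compound 2 to compound 3 (within the scatter).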

Compound 3, half-maximal inhibitory concentration: 15700 nM
Estimate against measurement, compound 3: 1.6-fold (0.20 log units) below, and the stated range covers the measured number.
By their numbers in this assay, from the lowest: compounds 2, 1 and 3 (each within the scatter of the next).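

In this assay, 3-nitrophenyl gives a 1.6-fold higher number from compound 2 to compound 3 (0.20 log units; within the scatter) and a 1.2-fold higher number from compound 1 to compound 3 (0.08 log units; within the scatter), so compound 3 stands level with both earlier compounds. This place on the core has now carried 4-fluorophenyl, 4-methoxyphenyl and 3-nitrophenyl, and the new group's larger heavy-atom count and extra hydrogen-bond acceptor relative to 4-methoxyphenyl come with no separation beyond the scatter, which extends the earlier finding to a substituent of a different kind at a different ring location. Nothing available on these compounds speaks to what lies behind this result.

Still open, as far as these compounds go, is whether any change at this place can separate compounds beyond the scatter. An amine on the phenyl ring, or a longer alkyl chain in place of the whole ring, would test this, and the compounds shown give no hint of the outcome.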